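The compounds below may be only part of what the source reports. "The series", "measured", "known", "first", "only" and "open" are said of these compounds alone.

Compound 2, `CCC(Sc1nc2c(cnn2C)c(=O)n1-c1ccccc1)c1ccccc1`, has the lowest number among the three compounds whose results are known. In an assay on isolated protein for inhibition of aldehyde dehydrogenase 1A1 (Homo sapiens) (on this read-out higher numbers stand for weaker inhibition and lower numbers for stronger inhibition), compound 2 gives 150 nM. Compound 3, `CC(C)C(Sc1nc2c(cnn2C)c(=O)n1-c1ccccc1)c1ccccc1`, gives 380 nM in this assay, and compound 1, `COc1cccc(C(C)Sc2nc3c(cnn3C)c(=O)n2-c2ccccc2)c1`, gives 451 nM.

The next compound, compound 4, `C[C@H](Sc1nc2c(cnn2C)c(=O)n1-c1ccccc1)c1ccccc1`, is built from compound 2 by one change: 1-phenylethyl in place of 1-phenylpropyl on a sulfur. Among the compounds with values here, only one of the measured steps bears on this change, and only indirectly. From compound 2 to compound 3 the chain grew by methyl in place of hydrogen on a saturated chain carbon bound to two saturated chain carbons, and this assay moved by a 2.5-fold higher number from compound 2 to compound 3 (0.40 log units; beyond the scatter). Within the data shown here, the step to compound 4 goes the other way, towards a shorter chain, and no measured pair shows such a shortening on its own. Compound 1 also carries a 1-arylethyl group on the sulfur, but it differs from compound 2 in a second place as well, so its higher number cannot be laid at the chain alone. Compound 4 is therefore expected to stay close to compound 2, with a step of a 1.7-fold higher number from compound 2 to compound 4 (0.22 log units; within the scatter) and wide uncertainty. Compound 4 is estimated at 250 nM, between 90 nM and 700 nM.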

Compound 4, half-maximal inhibitory concentration: 1410 nM
Compound 4: the middle estimate sits 5.6-fold (0.75 log units) below what was measured; the whole stated range lies below it.
By their numbers in this assay, from the lowest: compound 2; then compounds 3 and 1 (each within the scatter of the next); then compound 4.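

In this assay, within the data shown here, replacing 1-phenylpropyl with 1-phenylethyl on a sulfur gives a 9.4-fold higher number from compound 2 to compound 4 (0.97 log units; beyond the scatter), showing that shortening this chain can matter far more than the earlier compounds suggested. Read together with a 2.5-fold higher number from compound 2 to compound 3 (0.40 log units; beyond the scatter), it shows the number rising in both directions of change at this position: the added methyl and the shorter chain each lead away from compound 2, and the shortening gives the larger step, so no simple rule of more or less chain fits compound 2, compound 3 and compound 4. Nothing measured here explains the size of this step.

The entering 1-phenylethyl has a defined stereocentre while the 1-phenylpropyl of compound 2 has none, so the compounds shown do not separate the effect of the shorter chain from that of a single mirror-image form, and the opposite form of 1-phenylethyl remains an open comparison. Also open, as far as these compounds go, is how a longer unbranched chain on the same carbon, such as 1-phenylbutyl, would compare with compound 2.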